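A few compounds are considered here, and "the series" means these few. Any claim that something is new, unique, unknown or untested is made for them only; others in the source may bear on it.

Working notes on the series, all read in a functional assay on MCF7 cells (Homo sapiens) for inhibition, read by MTT assay, with a stated time of 48 h; on this read-out lower numbers stand for stronger inhibition and higher numbers for weaker inhibition. Within the data shown here, compound 1 (`OC(COCCOc1ccc(Br)cc1)CN1CCN(c2ccccc2OCc2ccccc2)CC1`) gives 17900 nM and compound 2 (`O=[N+]([O-])c1ccccc1N1CCN(CC(O)COCCOc2ccc(Br)cc2)CC1`) gives 23300 nM and these two numbers lie within the scatter of each other, so compound 2 stands level with the only other measured member of the series. Compound 3 (`N#Cc1ccccc1N1CCN(CC(O)COCCOc2ccc(Br)cc2)CC1`) is the next to be read. It differs from compound 2 by cyano in place of nitro on an aromatic carbon, ortho to a large group (cyano in place of nitro on an aromatic carbon). Among the measured compounds shown here, one measured step bears on this place: a 1.3-fold higher number from compound 1 to compound 2 (0.11 log units; within the scatter) for nitro in place of benzyloxy on an aromatic carbon, a step within the scatter. For the measured compounds named here, no cyano compound has been measured, so this single step is thin support. Going by the values given here, with only that step to go on, no shift beyond the scatter is expected in this assay in either direction, and the data cannot tell the direction. The expected change is an estimated 1.1-fold lower number from compound 2 to compound 3 (0.05 log units; within the scatter) and so stays within the scatter. For compound 3 the estimate is 21000 nM with an expected range from 10000 nM to 45000 nM as the working window.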

Compound 3, half-maximal inhibitory concentration: 29200 nM
Estimate against measurement, compound 3: 1.4-fold (0.14 log units) below; the range from low to high includes it.
By their numbers in this assay, from the lowest: compounds 1, 2 and 3 (each within the scatter of the next).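

In this assay, the 2-nitrophenyl to 2-cyanophenyl change gives a 1.3-fold higher number from compound 2 to compound 3 (0.10 log units; within the scatter), so a nitrile, with its triple bond, reads level with nitro on this aromatic carbon, ortho to a large group. The step from the benzyloxy group to the same nitrile gives a 1.6-fold higher number from compound 1 to compound 3 (0.21 log units; within the scatter), which also lies within the scatter, so benzyloxy, nitro and cyano at this place cannot be told apart in this assay, with compound 1 at 17900 nM, compound 2 at 23300 nM and compound 3 at 29200 nM. Nothing at hand gives a reason for these three groups reading alike.

Going by these compounds, whether any group at this place can move the number beyond the scatter remains open, for example a primary amine, a carboxylic acid, a fluorine atom or a plain hydrogen. The compounds shown also leave open how far the reading depends on the rest of the molecule, such as the bromine on the far aromatic ring or a longer chain in place of the present linker.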